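Adding a Second Chloro to a Cytotoxic Purine Scaffold

The source may hold more compounds than are shown below. What is called first, only, known or untested is meant among the compounds shown, and "the series" means these compounds.

Measured compounds:
Compound 1, `ClCc1cccc(Cn2cnc3ncnc(Cl)c32)c1`: 9330 nM
Compound 2, `ClCc1cccc(Cn2cnc3c(Cl)nc(Cl)nc32)c1`: 40700 nM

Both compounds were tested in a functional assay on NCI-H226 cells (Homo sapiens) for cytotoxicity, read by sulforhodamine B assay, with a stated time of 48 h; a lower number here means that less compound is tolerated, a higher number that more compound is tolerated. Compound 1 gives the lowest number of the two, 9330 nM, and compound 2, which carries two chloro groups on the shared core, gives 40700 nM, a gap beyond the usual scatter.

Compound 3, `ClCc1cccc(Cn2cnc3nc(Cl)nc(Cl)c32)c1`, has not yet been measured in this assay. It differs from compound 1 by chloro in place of hydrogen on an aromatic carbon. For the measured compounds named here, no measured pair shows exactly this change, so the expected size of the step rests on the two values above: the only other compound with two chloro groups, compound 2, tolerates more compound than compound 1. For compound 3 a moderate rise in the number is therefore expected, a step of a 2.1-fold higher number from compound 1 to compound 3 (0.33 log units; beyond the scatter). The estimate for compound 3 is 20000 nM, with a range from 7000 nM to 60000 nM.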

Compound 3, concentration lethal to 50% of the cells: 20000 nM
Beside the measured number, compound 3's estimate shows no gap at the digits printed; the measured number falls inside the stated range.
By their numbers in this assay, from the lowest: compound 1; then compound 3; then compound 2.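

For the compounds shown here, compound 3 gives the first direct reading of a single change on the shared core. In this assay chloro in place of hydrogen on the aromatic carbon between two ring nitrogen atoms brings a 2.1-fold higher number from compound 1 to compound 3 (0.33 log units; beyond the scatter) and this modest step lies beyond the usual scatter, so more compound is tolerated once this one atom is swapped, something compounds 1 and 2 could not show since they differ in more than one place. Nothing measured here explains why the number rises at this carbon.

On these data alone, whether this carbon would respond in the same way to a different group, such as an amine or a methoxy group, remains open. So does whether the same step would appear in a cell line other than this one.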